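Working notes on four analogues and their cytotoxicity

The source may hold more compounds than are shown below. What is called first, only, known or untested is meant among the compounds shown, and "the series" means these compounds.

Measured so far:
compound 1 `CCOC(=O)[C@@H]1C[C@@]23CN(C)C[C@@H](CCC4=C2[C@@H]1CC4=O)C31CC[C@](CC)(OC)OC1` — > 40000 nM
compound 2 `CC[C@]1(OC)CCC2(CO1)[C@@H]1CCC3=C4[C@H](CC3=O)[C@H](C(=O)OC)C[C@@]42CN(C)C1` — > 40000 nM
compound 3 `CCC1=CCC2(CO1)[C@@H]1CCC3=C4[C@H](CC3=O)[C@H](C(=O)OC)C[C@@]42CN(C)C1` — > 40000 nM

In a functional assay on A549 cells (Homo sapiens) for cytotoxicity, read by MTT assay, with a stated time of 48 h (a lower number here means a stronger inhibitor, a higher number a weaker inhibitor), compound 1 gives > 40000 nM, which is a limit of the assay and not a number. In this assay compound 2 gives > 40000 nM, likewise a limit. Compound 3 also sits at a limit, > 40000 nM. Compounds 2 and 1 differ in one place, (methyl in place of hydrogen on a saturated chain carbon bound to an oxygen next to a carbonyl group); the step that the two limits leave unreadable from compound 2 to compound 1 cannot be read, since the limit of > 40000 nM in this assay, at which 3 of the 3 values shown sit, holds both of its ends. Compound 4 `COC(=O)[C@@H]1C[C@@]23CN(C)C[C@@H](CCC4=C2[C@@H]1CC4=O)C31CC=C(C(C)C)OC1` has not yet been measured. It differs from compound 3 by methyl in place of hydrogen on a saturated chain carbon bound to a double-bonded ring carbon and a saturated chain carbon, the same kind of change as that from compound 2 to compound 1, though the place differs: in compound 1 the carbon is bound to an oxygen next to a carbonyl group, in compound 4 to a double-bonded ring carbon and a saturated chain carbon. The difference between the cores of compound 2 and compound 3 is not broken down here. Because all three measured values sit at the limit of > 40000 nM in this assay, at which 3 of the 3 values shown sit, the methyl addition is expected to leave compound 4 at the same limit, an expected step that the limit leaves unreadable from compound 3 to compound 4. Compound 4 is estimated at 60000 nM, between 20000 nM and 200000 nM.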

Compound 4, half-maximal inhibitory concentration: > 40000 nM
Compound 4: only a limit was reported; the forecaster's own chance of this, stated with the estimate: 85%; the middle value is on the limit's open side.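

In this assay compound 4 gives > 40000 nM, which is a limit of the assay and not a number. Among these compounds, no step from compound 3 to compound 4 can be read, because both values are limits: the limit of > 40000 nM in this assay, at which 4 of the 4 values shown sit. The compounds shown leave open whether ethyl to isopropyl changes cytotoxicity at all.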